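Swapping the sulfonyl aryl group in a kinase-type inhibitor series

The source may report more compounds than this note shows. Statements on the series, on what has been measured and on what is new or still open speak of the compounds shown alone.

The measured compounds and their values:
Compound 1, `Cn1c(=O)c(S(=O)(=O)c2ccccc2)cc2cnc(Nc3ccc4ncccc4c3)nc21`, 100000 nM
Compound 2, `COc1ccc(S(=O)(=O)c2cc3cnc(Nc4ccc5[nH]ccc5c4)nc3n(C)c2=O)cc1`, 300 nM
Compound 3, `COc1ccc(S(=O)(=O)c2cc3cnc(Nc4cccc5[nH]ccc45)nc3n(C)c2=O)cc1`, 5000 nM

Of the compounds shown here, three sharing one core have been tested in a functional assay on K562 cells (Homo sapiens) for inhibition, read by trypan blue exclusion, with a stated time of 72 h; a higher number here means a weaker inhibitor, a lower number a stronger inhibitor. Compound 2 gives the lowest number of the three: in this assay compound 2 gives 300 nM. Its nearest neighbour is compound 3, and the step of a 17-fold higher number from compound 2 to compound 3 (1.22 log units; beyond the scatter) comes from 1H-indol-4-yl in place of 1H-indol-5-yl on a nitrogen on an aromatic ring. Compound 1 is furthest away; it differs from compound 2 in two places, so only its value can be compared, and in this assay compound 1 gives 100000 nM.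

The unmeasured compound 4, `Cn1c(=O)c(S(=O)(=O)c2ccc(N)cc2F)cc2cnc(Nc3ccc4[nH]ccc4c3)nc21`, is reached from compound 2 by 4-amino-2-fluorophenyl in place of 4-methoxyphenyl on a sulfonyl sulfur. No measured step touches the group on the sulfonyl sulfur, so the only step shown, from compound 2 to compound 3, lies elsewhere and gives no direct guide. Without such a precedent the expected step of a 1.7-fold higher number from compound 2 to compound 4 (0.22 log units; within the scatter) is small, with no direction to be read from the data. Compound 4 is therefore estimated at 500 nM, with a range of 100 nM to 3000 nM.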

Compound 4, half-maximal inhibitory concentration: 1500 nM
Compound 4: the middle estimate sits 3.0-fold (0.48 log units) below what was measured; measured number inside the range.
By their numbers in this assay, from the lowest: compound 2; then compound 4; then compound 3; then compound 1.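

Among the compounds shown here, this is the first measured step at the sulfonyl sulfur, and in this assay it shows that the group there is not interchangeable: a 5.0-fold higher number from compound 2 to compound 4 (0.70 log units; beyond the scatter) follows from 4-amino-2-fluorophenyl in place of 4-methoxyphenyl. For the compounds shown here, the two groups have the same number of heavy atoms and the same six-membered aromatic ring of carbon only, yet the entering group carries one hydrogen-bond donor where the leaving group carries none, and the single step joins the loss of the methoxy group with the gain of both an amine and a fluorine. No measurement here bears on why the number rises.

Whether the amine or the fluorine accounts for the step remains open, as does the outcome with either one alone on the aryl ring, or with a carboxylic acid or a longer alkoxy chain in place of the methoxy group. From the compounds shown here alone, it also remains open whether 1H-indol-5-yl keeps its lead over 1H-indol-4-yl on the nitrogen when 4-amino-2-fluorophenyl sits on the sulfonyl sulfur.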